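A few compounds are considered here, and "the series" means these few. Any claim that something is new, unique, unknown or untested is made for them only; others in the source may bear on it.

Measured compounds in a functional assay on DU-145 cells (Homo sapiens) for cytotoxicity, read by sulforhodamine B assay, with a stated time of 2 days, tested at 100 uM; a higher number here means more inhibition at the concentration tested (going by the name of the read-out), a lower number less inhibition:
- compound 1, `CCCc1nc2c(-c3ccc(Cl)cc3)n[nH]c2c(=O)n1NC(=O)c1ccccc1`: 89.4%
- compound 2, `CCCCc1nc2c(-c3ccc(Cl)cc3)n[nH]c2c(=O)n1NC(=O)c1ccccc1`: 93.1%
- compound 3, `CCCCCc1nc2c(-c3ccc(Cl)cc3)n[nH]c2c(=O)n1NC(=O)c1ccccc1`: 88.7%

Compound 3 sits lowest of the three numbers, but its nearest neighbour is compound 1, a number 0.7 percentage points lower from compound 1 to compound 3 (within the scatter), and its furthest is compound 2, a number 4.4 percentage points lower from compound 2 to compound 3 (within the scatter); both gaps lie within the scatter, so no order among the three can be read from these values. The chain-length steps give the same picture: a number 3.7 percentage points higher from compound 1 to compound 2 (within the scatter).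

Compound 4, `CCCCCc1nc2c(-c3ccc(Cl)cc3)n[nH]c2c(=O)n1NC(=O)c1cccc(C)c1`, is compound 3 with the change (methyl in place of hydrogen on an aromatic carbon). Within the data shown here, none of the measured steps touches the benzamido ring; all of them vary the saturated chain on the shared core, and all three stayed within the scatter. Among the measured compounds shown here, there is therefore no measured step that bears directly on this change, and no ground in the data for expecting a shift in this assay beyond the scatter. Compound 4 is expected to show a number 0.3 percentage points higher from compound 3 to compound 4 (within the scatter), i.e. no step beyond the scatter. The estimate for compound 4 in this assay is 89%, in the range 76% to 97%.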

Compound 4, a percentage reported as inhibition, at one concentration (the size of the read-out at that concentration, not a potency): 88.8%
Estimate against measurement, compound 4: 0.2 percentage points above, and the stated range covers the measured number.
By their numbers in this assay, from the lowest: compounds 3, 4, 1 and 2 (each within the scatter of the next).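

In this assay the one step shown on the benzamido ring, benzamido to ((3-methylphenyl)carbonyl)amino with the pentyl chain held constant, gives a number 0.1 percentage points higher from compound 3 to compound 4 (within the scatter) and so stays within the scatter. Among these compounds, the earlier steps varied only the saturated chain, so this is the first indication that the number in this read-out stays level with a methyl in place of hydrogen on this aromatic carbon, meta to a large group, though it rests on a single pair of compounds. Nothing measured here accounts for the result, and the data give no explanation for it.

Still open, going by these compounds, is whether a larger or different group at this aromatic carbon, such as a methoxy group, a nitrile, an amine or a carboxylic acid, would give a step beyond the scatter, and whether the same methyl would behave alike on the propyl and butyl compounds. Also open, on these data alone, is whether a much longer chain on the shared core would change the number, and, with only a single tested concentration in this read-out, how these compounds compare in potency.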